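A few compounds are considered here, and "the series" means these few. Any claim that something is new, unique, unknown or untested is made for them only; others in the source may bear on it.

Measured so far:
- compound 1, `O=C(/C=C/c1cccc(O)c1)c1cccc(-n2cc(-c3ccccc3)[nH]c2=O)c1`: 3350 nM
- compound 2, `O=C(/C=C/c1cccc(O)c1)c1cccc(-n2cc(-c3ccc(Cl)cc3)[nH]c2=O)c1`: 2780 nM
- compound 3, `COc1cc(/C=C/C(=O)c2cccc(-n3cc(-c4ccccc4)[nH]c3=O)c2)cc(OC)c1OC`: 1430 nM

All three were tested in a functional assay on NCI-H23 cells (Homo sapiens) for inhibition; a higher number here means a weaker inhibitor of growth, a lower number a stronger inhibitor of growth. Compound 2 stands second highest of the three numbers, with compound 1 nearest and compound 3 furthest; both gaps sit within the scatter of repeated measurements, so no ordering among them can be claimed. Among the measured compounds shown here, the one counted step among the measured compounds, a 1.2-fold lower number from compound 1 to compound 2 (0.08 log units; within the scatter), concerns a chloro in place of hydrogen on an aromatic carbon and changes nothing beyond the scatter.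

Compound 4, `COc1cc(/C=C/C(=O)c2cccc(-n3cc(-c4ccc(Cl)cc4)[nH]c3=O)c2)ccc1O`, is not yet measured. It differs from compound 2 in one place: 4-hydroxy-3-methoxyphenyl in place of 3-hydroxyphenyl on a double-bonded chain carbon bound to a double-bonded chain carbon. For the measured compounds named here, no measured step touches the aryl on the double-bonded chain carbon directly. Compound 1 and compound 3 differ there too, with values within the scatter of each other, so those two numbers hint that changing this aryl leaves the growth inhibition little altered.

For compound 4 the expectation is therefore a number close to that of compound 2, the expected step being a 1.3-fold lower number from compound 2 to compound 4 (0.10 log units; within the scatter). The estimate for compound 4 in this assay is 2200 nM, expected to fall between 800 nM and 6000 nM.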

Compound 4, concentration for 50% growth inhibition: 3180 nM
The estimate for compound 4 lay 1.4-fold (0.16 log units) below the measured number; measured number inside the range.
By their numbers in this assay, from the lowest: compounds 3, 2, 4 and 1 (each within the scatter of the next, the first and the last beyond it).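

In this assay, the exchange of 3-hydroxyphenyl for 4-hydroxy-3-methoxyphenyl on the double-bonded chain carbon can now be read directly as a single step, a 1.1-fold higher number from compound 2 to compound 4 (0.06 log units; within the scatter), with the rest of the structure held constant. Even though the entering group has 9 heavy atoms in place of 7 and 2 hydrogen-bond acceptors in place of 1, no difference in growth inhibition can be claimed for this pair, so this position accepts this particular exchange without a measurable penalty. No supporting data bear on this result, so the reason for it remains unknown.

All the groups shown at this position are phenyl rings carrying hydroxy or methoxy groups, so it remains open whether an amine or a carboxylic acid on this ring would give a number beyond the scatter. Also open, from the compounds shown here alone, is whether chloro in place of hydrogen on an aromatic carbon would behave the same way in compounds carrying 4-hydroxy-3-methoxyphenyl as it does in those carrying 3-hydroxyphenyl.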